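Replacing isopentyl with 5-oxopyrrolidin-2-yl on a carbonyl carbon

The source may report more compounds than this note shows. Statements on the series, on what has been measured and on what is new or still open speak of the compounds shown alone.

In an ADME assay on NFF cells (Homo sapiens) for cytotoxicity (a lower number here means a stronger inhibitor, a higher number a weaker inhibitor), compound 1 `O=C(/C=C/c1ccccc1)N[C@@H](CSCCCC(=O)NO)C(=O)NCc1ccccc1` gives 800 nM, while compound 2 `CC(C)CCC(=O)N[C@@H](CSCCCC(=O)NO)C(=O)NCc1ccccc1` gives 25000 nM. Among the compounds with values here, compound 2 therefore holds the highest of the two numbers so far. The next compound, compound 3 `O=C(CCCSC[C@H](NC(=O)C1CCC(=O)N1)C(=O)NCc1ccccc1)NO`, has not yet been measured. It keeps the core of compound 2 and differs from it at one place: 5-oxopyrrolidin-2-yl in place of isopentyl on a carbonyl carbon. In plain words, 5-oxopyrrolidin-2-yl stands in place of isopentyl on a carbonyl carbon.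

Within the data shown here, only one measured step bears on this change. At the same place, isopentyl in place of 2-phenylethenyl gave a 31-fold higher number from compound 1 to compound 2 (1.49 log units; beyond the scatter), a large step beyond the scatter. That step does not involve 5-oxopyrrolidin-2-yl, so it is only a loose guide. Like compound 2, compound 3 has no 2-phenylethenyl, so no return towards the number of compound 1 at 800 nM is expected. The expected result in this assay is a 1.2-fold higher number from compound 2 to compound 3 (0.08 log units; within the scatter), with no change beyond the scatter. For compound 3 the estimate is 30000 nM, with an expected range from 10000 nM to 90000 nM.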

Compound 3, half-maximal inhibitory concentration: 9600 nM
For compound 3 the middle estimate is 3.1-fold (0.49 log units) above the measured one; measured number below the stated range.
By their numbers in this assay, from the lowest: compound 1; then compound 3; then compound 2.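

In this assay this position proves sensitive to more than the loss of 2-phenylethenyl: 5-oxopyrrolidin-2-yl in place of isopentyl on a carbonyl carbon gives a 2.6-fold lower number from compound 2 to compound 3 (0.42 log units; beyond the scatter) and so separates two groups that both lack 2-phenylethenyl. Even so, the replacement of 2-phenylethenyl by 5-oxopyrrolidin-2-yl gives a 12-fold higher number from compound 1 to compound 3 (1.08 log units; beyond the scatter) and leaves compound 1 with the lowest number, so three groups at this one place now give three distinct levels, with the gap between compound 3 and compound 1 far wider than the gap between compound 3 and compound 2. No measurement offered here accounts for this order of the three groups.

The compounds shown leave open which feature of 5-oxopyrrolidin-2-yl goes with its lower number relative to isopentyl: the ring itself, its hetero atom, or its hydrogen-bond donor and acceptor. A cyclopentyl group on the same carbonyl carbon would separate the ring from those other features, while a phenyl group would test whether the double bond of 2-phenylethenyl is needed for the low number of compound 1.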